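The source may hold more compounds than are shown below. What is called first, only, known or untested is meant among the compounds shown, and "the series" means these compounds.

Working notes on the imidazole ester series.

Three compounds have numbers in an assay on microsomes from MCF7 cells for inhibition of cytochrome P450 26A1 (Homo sapiens), read by scintillation counting, with a stated time of 1 h (a higher number here means a weaker inhibitor, a lower number a stronger inhibitor), so far. Compound 1 `COC(=O)C(C)(C)C(c1ccc(Nc2ccccc2)cc1)n1ccnc1` gives 10 nM in this assay. Among the measured compounds shown here, compound 2 `COC(=O)C(C)(C)C(c1ccc(Nc2nc3ccccc3s2)cc1)n1ccnc1` gives 100 nM in this assay, and the single one-place step in hand, a 10-fold higher number from compound 1 to compound 2 (1.00 log units; beyond the scatter), is a change on the aniline side of the shared core, not in the chain. Compound 3 `COC(=O)[C@@H](C)[C@H](c1ccc(Nc2ccccc2)cc1)n1ccnc1` gives 40 nM in this assay, which puts compound 3 second highest of the three numbers: compound 2 sits higher by a margin beyond the scatter, and compound 1 sits lower by a margin beyond the scatter.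

The next compound is compound 4 `COC(=O)[C@H](C)[C@H](c1ccc(Nc2ccccc2)cc1)n1ccnc1`. It differs from compound 3 as follows: the two compounds have the same atoms and bonds and differ only in configuration as drawn: 1 of 2 stereo elements differ; a stereocentre at a saturated chain carbon is drawn S in compound 3 and R in compound 4. For the measured compounds named here, no measured step in this set bears on a change of configuration; the only step in hand, a 10-fold higher number from compound 1 to compound 2 (1.00 log units; beyond the scatter), concerns a different part of the molecule and gives no guidance on direction here. For compound 4 the working expectation is therefore a step of a 1.3-fold higher number from compound 3 to compound 4 (0.10 log units; within the scatter) in this assay, with wide uncertainty in either direction. Compound 4 is estimated at 50 nM in this assay, within a range of 10 nM to 250 nM.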

Compound 4, half-maximal inhibitory concentration: 26 nM
For compound 4 the middle estimate is 1.9-fold (0.28 log units) above the measured one; low and high end bracket the measured number.
By their numbers in this assay, from the lowest: compound 1; then compounds 4 and 3 (each within the scatter of the next); then compound 2.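

In this assay, the change of configuration at this saturated chain carbon, drawn S in compound 3 and R in compound 4, gives a 1.5-fold lower number from compound 3 to compound 4 (0.19 log units; within the scatter), so the assay does not separate these two drawn forms. Among the compounds shown here, the earlier compounds offered only a change on the aniline side of the shared core, a 10-fold higher number from compound 1 to compound 2 (1.00 log units; beyond the scatter), which lies beyond the scatter; this pair gives the first one-place reading in the chain, and at this stereocentre the printed step lies within it. The reading applies to this stereocentre alone, because nothing else separates the two compounds: the fact that compounds 3 and 4 differ only in the configuration as drawn

Still open, on these data alone, is whether the same holds at the other stereocentre, which is drawn alike in compound 3 and compound 4, and whether it holds with the 1,3-benzothiazol-2-yl group of compound 2 in place of phenyl. Also open, as far as these compounds go, is what a carboxylic acid or an amide in place of the methyl ester, or a longer chain, would give in either configuration.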